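The compounds below may be only part of what the source reports. "The series", "measured", "known", "first", "only" and "open" are said of these compounds alone.

Measured compounds:
Compound 1, `CCN(CC)CCCNc1nc(-c2ccc(NC(=O)Nc3ccccc3)cc2)nc2ccsc12` — 730 nM
Compound 2, `CCN(CC)CCCNc1nc(-c2ccc(NC(=O)Nc3ccc(Cl)cc3)cc2)nc2ccsc12` — 58 nM

In a functional assay on HT-29 cells (Homo sapiens) for cytotoxicity, read by MTT assay, with a stated time of 72 h (on this read-out higher numbers stand for weaker inhibition and lower numbers for stronger inhibition), compound 1 gives 730 nM and compound 2 gives 58 nM. Going by the values given here, compound 2 therefore holds the lowest of the two numbers in this assay, with compound 1 as its only neighbour, and the step of a 13-fold lower number from compound 1 to compound 2 (1.10 log units; beyond the scatter) is the single measured change in this set.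

Compound 3, `CCN(CC)CCNc1nc(-c2ccc(NC(=O)Nc3ccc(Cl)cc3)cc2)nc2ccsc12`, has not yet been measured in this assay. It differs from compound 2 only in the chain that carries the basic amine: diethylamino in place of (diethylamino)methyl on a saturated chain carbon, two bonds along the chain from a nitrogen on an aromatic ring. The change leaves the chloro group, the urea and the shared core of compound 2 untouched.

Among the compounds with values here, no measured step speaks to this kind of change. Within the data shown here, the one step available, a 13-fold lower number from compound 1 to compound 2 (1.10 log units; beyond the scatter), concerns a chloro group on an aromatic carbon and says nothing about the length of the amine-bearing chain. With no evidence in either direction, the expectation for compound 3 is a step of about a 1.2-fold higher number from compound 2 to compound 3 (0.08 log units; within the scatter) in this assay, not beyond the scatter, with the range kept wide to reflect that uncertainty. Compound 3 is thus estimated at 70 nM in this assay, with a range from 20 nM to 250 nM.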

Compound 3, half-maximal inhibitory concentration: 150 nM
Estimate against measurement, compound 3: 2.1-fold (0.33 log units) below, within the range that was stated.
By their numbers in this assay, from the lowest: compound 2; then compound 3; then compound 1.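

Shortening the chain from (3-(diethylamino)propyl)amino to (2-(diethylamino)ethyl)amino gives the first measured outcome for a change at this position: in this assay there is a 2.6-fold higher number from compound 2 to compound 3 (0.41 log units; beyond the scatter). The length of the amine-bearing chain therefore registers in this read-out, although this step is smaller than a 13-fold lower number from compound 1 to compound 2 (1.10 log units; beyond the scatter), which came with the chloro group and remains the larger of the two measured single changes. Nothing available on these compounds bears on why the shorter chain goes with the higher number.

The compounds shown give only one step in chain length, measured with the chloro group in place, so it stays open whether the same shortening would give a similar step without that group and whether a longer chain would move the number further in the opposite direction. As far as these compounds go, it also stays open how the read-out would respond if the diethylamino group at the end of the chain gave way to another amine, such as dimethylamino, piperidine or morpholine.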